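Swapping the end group on a carbonyl carbon

The source may hold more compounds than are shown below. What is called first, only, known or untested is meant among the compounds shown, and "the series" means these compounds.

Values in an ADME assay on CCRF-CEM cells (Homo sapiens) for cytotoxicity, with a stated time of 4 days (on this read-out lower numbers stand for higher toxicity in this test and higher numbers for lower toxicity in this test), are:
- compound 1 `CNC(=O)CCCCn1c(=O)c(C)cn([C@@H]2O[C@H](CO[Si](C)(C)C(C)(C)C)[C@@]3(OS(=O)(=O)C=C3N)[C@H]2O[Si](C)(C)C(C)(C)C)c1=O` gives 10000 nM
- compound 2 `COC(=O)CCCC(=O)n1c(=O)c(C)cn([C@@H]2O[C@H](CO[Si](C)(C)C(C)(C)C)[C@@]3(OS(=O)(=O)C=C3N)[C@H]2O[Si](C)(C)C(C)(C)C)c1=O` gives 9900 nM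
- compound 3 `Cc1cn([C@@H]2O[C@H](CO[Si](C)(C)C(C)(C)C)[C@@]3(OS(=O)(=O)C=C3N)[C@H]2O[Si](C)(C)C(C)(C)C)c(=O)n(C(=O)CCCC(=O)N(C)C)c1=O` gives 9500 nM

Compound 3 stands level with the other two, since all three values lie within the scatter of one another. Compound 4 `Cc1cn([C@@H]2O[C@H](CO[Si](C)(C)C(C)(C)C)[C@@]3(OS(=O)(=O)C=C3N)[C@H]2O[Si](C)(C)C(C)(C)C)c(=O)n(C(=O)CCCC(=O)OCc2ccccc2)c1=O` has not been measured and carries benzyloxy in place of dimethylamino on a carbonyl carbon as its only difference. The closest evidence, a swap on that same carbonyl carbon, is a 1.0-fold lower number from compound 2 to compound 3 (0.02 log units; within the scatter) and shows no real change. The wider changes, a 1.0-fold lower number from compound 1 to compound 2 (0.00 log units; within the scatter) and a 1.1-fold lower number from compound 1 to compound 3 (0.02 log units; within the scatter) likewise, show none. Among the measured compounds shown here, no measured compound carries benzyloxy, so the range stays wide. The expected result is a 1.1-fold lower number from compound 3 to compound 4 (0.02 log units; within the scatter) and no step beyond the scatter is anticipated. Compound 4 is estimated at 9000 nM (expected range 4500 nM to 18000 nM).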

Compound 4, half-maximal cytotoxic concentration: 9200 nM
The estimate for compound 4 lay 1.0-fold (0.01 log units) below the measured number; measured number inside the range.
By their numbers in this assay, from the lowest: compounds 4, 3, 2 and 1 (each within the scatter of the next).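

Benzyloxy puts a six-membered aromatic ring on this carbonyl carbon, yet in this assay the swap gives a 1.0-fold lower number from compound 3 to compound 4 (0.01 log units; within the scatter) and stays within the scatter. Phenyl in place of hydrogen on a saturated chain carbon bound to an oxygen next to a carbonyl group gives a 1.1-fold lower number from compound 2 to compound 4 (0.03 log units; within the scatter) and also stays within the scatter. So an end group with an aromatic ring reads the same here as methoxy and dimethylamino, and nothing measured offers a reason for this. On these data alone, whether a free carboxylic acid or a primary amine at this end would also read the same stays open.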